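The source may report more compounds than this note shows. Statements on the series, on what has been measured and on what is new or still open speak of the compounds shown alone.

Working notes on the series, read in a functional assay on K562 cells (Homo sapiens) for cytotoxicity, read by MTT assay; a lower number here means a stronger inhibitor, a higher number a weaker inhibitor. Compound 1 `CCCCCCCCSC1=CC(=O)C(C[C@]2(C)[C@@H](C)CC[C@]3(C)C(C)=CCC[C@@H]23)=CC1=O` gives > 100000 nM, which is a limit of the assay and not a number. Two other compounds give numbers: compound 2 `CC1CCC[C@H]2[C@](C)(CC3=CC(=O)C(Cl)=CC3=O)[C@@H](C)CC[C@]12C` gives 11200 nM, and compound 3 `CC1=CCC[C@H]2[C@](C)(CC3=CC(=O)C4=C(SCCS4)C3=O)[C@@H](C)CC[C@]12C` gives 91000 nM. Compound 1 therefore has no number of its own, and any step from it can only be judged against the values of these two compounds.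

Compound 4 `CC1=CCC[C@H]2[C@](C)(CC3=CC(=O)C(Sc4ccccc4)=CC3=O)[C@@H](C)CC[C@]12C` has not yet been measured in this assay. Its change from compound 1 is phenyl in place of octyl on a sulfur, which also reads as octylsulfanyl to phenylsulfanyl. Within the data shown here, no measured pair isolates this change, so the expectation rests only on the spread of the numbers so far. A step towards a stronger inhibitor is expected, of moderate size, with some chance that the result stays at the limit. The reference points for that expectation are compound 3 at 91000 nM and compound 2 at 11200 nM, and a result in the range they mark is expected. The estimated step is an at least 3.3-fold lower number from compound 1 to compound 4 (0.52 log units; beyond the scatter). For compound 4 the expected value is 30000 nM, with an estimated range of 8000 nM to 100000 nM.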

Compound 4, half-maximal inhibitory concentration: 15200 nM
The estimate for compound 4 lay 2.0-fold (0.30 log units) above the measured number; the range from low to high includes it.
By their numbers in this assay, from the lowest: compounds 2 and 4 (each within the scatter of the next); then compound 3. At a limit, above all of these: compound 1.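

In this assay, among these compounds, phenyl in place of octyl on the sulfur is the only change that can be read as a single step, and it shows that this substituent alone can move the read-out off the limit, with an at least 6.5-fold lower number from compound 1 to compound 4 (0.81 log units; beyond the scatter). Compound 1 gives > 100000 nM, which is a limit of the assay and not a number. The step is therefore only a bound, and its true size stays unknown, because compound 1 has no number of its own: the limit of > 100000 nM in this assay, at which 1 of the 4 values shown sits.

The exchange brings in an aromatic ring and removes the open chain in one move, so this single pair cannot say which of the two matters; a butyl chain or a cyclohexyl ring on the same sulfur would begin to separate them. Also open, from the compounds shown here alone, is whether the phenyl ring tolerates further groups, such as an amine or a carboxylic acid, and how far the number in this assay would follow such a change.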